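Herbicidal acylthiourea series: chloro-to-methoxy step on the pyrimidine

The compounds below may be only part of what the source reports. "The series", "measured", "known", "first", "only" and "open" are said of these compounds alone.

Measured so far:
- compound 1, `COc1cc(Cl)nc(NC(=S)NC(=O)c2c(-c3ccc(Cl)cc3Cl)noc2C)n1`: 53.2%
- compound 2, `COc1cc(OC)n2s/c(=N\C(=O)c3c(-c4ccc(Cl)cc4Cl)noc3C)nc2n1`: 82.7%

Both compounds were tested in a functional assay on the whole organism for inhibition, with Chenopodium ficifolium as the target, with a stated time of 72 h, tested at 100 mg/L; a lower number here means less inhibition of growth, a higher number more inhibition of growth at the concentration tested. Compound 1 gives 53.2% and is the lowest of the two numbers; compound 2 gives 82.7%, a number that lies beyond the scatter above compound 1. Among the compounds with values here, no single-point step between these two is defined, since compound 2 carries a cyclised core rather than the open acylthiourea of compound 1, so their two values are noted only as they stand.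

The unmeasured compound 3, `COc1cc(OC)nc(NC(=S)NC(=O)c2c(-c3ccc(Cl)cc3Cl)noc2C)n1`, differs from compound 1 in one place: methoxy in place of chloro on an aromatic carbon. Methoxy in place of chloro on an aromatic carbon, the same difference cut one bond further out reading 4-chloro-6-methoxypyrimidin-2-yl to 4,6-dimethoxypyrimidin-2-yl.

Within the data shown here, no measured pair in this set isolates that change, so the expected size of the step rests on little. The dimethoxy pattern appears in compound 2 with its higher value of 82.7%, but on a different core. A modest move upward is expected, roughly at the edge of the scatter, expressed as a number 8.8 percentage points higher from compound 1 to compound 3 (within the scatter). For compound 3 the estimate in this assay is 62%, with a range from 42% to 82%.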

Compound 3, percent growth inhibition at one concentration: 78.6%
Beside the measured number, compound 3's estimate is 16.6 percentage points below it; low and high end bracket the measured number.
By their numbers in this assay, from the lowest: compound 1; then compounds 3 and 2 (each within the scatter of the next).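

In this assay, methoxy in place of chloro on the aromatic carbon next to the ring nitrogen gives a number 25.4 percentage points higher from compound 1 to compound 3 (beyond the scatter). Within the data shown here, this is the first reading that isolates a single change, and it shows that this position responds to substitution: going from 4-chloro-6-methoxypyrimidin-2-yl to 4,6-dimethoxypyrimidin-2-yl moves growth inhibition by more than the usual scatter while the open acylthiourea core of compound 1 stays intact. Nothing available on the compounds accounts for the size of this step, so it stands as an observation without a cause.

On these data alone, with one pair, it remains open whether the rise is specific to methoxy or would also follow from an ethoxy group, a methyl group, an amine or a fluorine on the same carbon. Also open, as far as these compounds go, is whether the step holds on the other side of the molecule's acyl portion, with a different aryl group in place of the dichlorophenyl, and whether it persists at concentrations other than the single one used in this assay.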